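The source may hold more compounds than are shown below. What is called first, only, known or untested is meant among the compounds shown, and "the series" means these compounds.

Measured in a functional assay on HCT-116 cells (Homo sapiens) for antiproliferative activity, read by MTT assay, with a stated time of 72 h; on this read-out lower numbers stand for stronger inhibition and higher numbers for weaker inhibition:
- Compound 1 `O=C1COc2ccc(-c3cnc(Cl)c(NS(=O)(=O)c4ccc(F)cc4)c3)cc2N1C1CCCCC1`: > 40000 nM
- Compound 2 `COc1ncc(-c2ccc3c(c2)N(c2ccc(F)cc2)C(=O)CO3)cc1NS(=O)(=O)c1ccc(F)cc1`: > 40000 nM

Neither entry is a number. Compound 1 gives > 40000 nM, which is a limit of the assay. Compound 2 gives > 40000 nM, which is also a limit, so it has no exact position on the scale of this assay. The two compounds therefore cannot be ranked against each other, and the whole measured picture comes down to the limit of > 40000 nM in this assay, at which 2 of the 2 values shown sit.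

The next compound is compound 3 `O=C1COc2ccc(-c3cnc(Cl)c(NS(=O)(=O)c4ccc(F)cc4)c3)cc2N1c1ccc(F)cc1`. It differs from compound 2 by chloro in place of methoxy on an aromatic carbon. The swap sits on a six-membered aromatic ring with 1 nitrogen, next to the ring nitrogen and ortho to a ((4-fluorophenyl)sulfonyl)amino group. Among the measured compounds shown here, no measured pair shows what such a swap does. The expectation therefore rests only on (the limit of > 40000 nM in this assay, at which 2 of the 2 values shown sit). The expected change a number no higher from compound 2 to compound 3 (the limit leaves the size open) is none beyond the usual scatter, and a further limit is the likeliest report. The estimated value for compound 3 is 40000 nM, with an expected range from 15000 nM to 80000 nM.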

Compound 3, half-maximal inhibitory concentration: 34200 nM
The estimate for compound 3 lay 1.2-fold (0.07 log units) above the measured number; the range from low to high includes it.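

In this assay, among the compounds shown here, compound 3 gives 34200 nM as the only exact number among the three compounds, so the series now has one point on the scale rather than limits alone. On these data alone, on the aromatic carbon next to the ring nitrogen and ortho to a ((4-fluorophenyl)sulfonyl)amino group, chloro in place of methoxy gives an at least 1.1-fold lower number from compound 2 to compound 3 (0.06 log units; that floor lies within the scatter) and no more can be read, since the starting value is a limit and the true size stays open. On the amide-type nitrogen in a ring, 4-fluorophenyl in place of cyclohexyl gives an at least 1.1-fold lower number from compound 1 to compound 3 (0.06 log units; that floor lies within the scatter) with the same reservation, so neither change is shown to go beyond the scatter, and most of the values remain limits: the limit of > 40000 nM in this assay, at which 2 of the 3 values shown sit.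

The compounds shown leave open how large either step really is, as compound 1 and compound 2 have no exact position on the scale. They also leave open whether an amine or a nitrile on that aromatic carbon, or a smaller chain such as ethyl on the ring nitrogen, would give a number clearly apart from that of compound 3.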